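Cytotoxicity notes: aryl variation on the shared core

The compounds below may be only part of what the source reports. "The series", "measured", "known", "first", "only" and "open" are said of these compounds alone.

Measured so far:
compound 1 `Cc1cc(-c2ccc(Cl)cc2)cc(C)c1Nc1ccnc(Nc2ccc(C#N)cc2)n1` gives 4190 nM in an ADME assay on MT4 cells (Homo sapiens) for cytotoxicity, read by MTT assay, with a stated time of 4 days; a lower number here means that less compound is tolerated, a higher number that more compound is tolerated
compound 2 `Cc1cc(-c2ccccc2C(F)(F)F)cc(C)c1Nc1ccnc(Nc2ccc(C#N)cc2)n1` gives 4210 nM in this assay

Compound 2 and compound 1 sit within the scatter of each other, with a 1.0-fold higher number from compound 1 to compound 2 (0.00 log units; within the scatter); on these two numbers nothing separates them.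

Compound 3 `Cc1cc(-c2cc(F)cc(F)c2)cc(C)c1Nc1ccnc(Nc2ccc(C#N)cc2)n1` is not yet measured. It differs from compound 2 by 3,5-difluorophenyl in place of 2-(trifluoromethyl)phenyl on an aromatic carbon. Going by the values given here, the only measured step that bears on this is the aryl swap at the same position, and that step, a 1.0-fold higher number from compound 1 to compound 2 (0.00 log units; within the scatter), was within the scatter. A second aryl swap at that position is therefore expected to give no step beyond the scatter in this assay, in either direction.

Compound 3 is expected at 4200 nM with a range of 2100 nM to 8400 nM. The step this estimate means is a 1.0-fold lower number from compound 2 to compound 3 (0.00 log units; within the scatter), and it is expected to fall within the scatter.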

Compound 3, half-maximal cytotoxic concentration: 3910 nM
Compound 3: middle estimate off by 1.1-fold (0.03 log units), on the high side, and the stated range covers the measured number.
By their numbers in this assay, from the lowest: compounds 3, 1 and 2 (each within the scatter of the next).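

In this assay a third substitution pattern on the phenyl group at this position gives a 1.1-fold lower number from compound 2 to compound 3 (0.03 log units; within the scatter) and also a 1.1-fold lower number from compound 1 to compound 3 (0.03 log units; within the scatter) on the same shared core. The three compounds therefore stay within the scatter of one another across 4-chlorophenyl, 2-(trifluoromethyl)phenyl and 3,5-difluorophenyl, and the change from 10 heavy atoms to 8 in the step to compound 3 brings no step beyond the scatter. No supporting data are available to explain this flat result.

As far as these compounds go, whether this holds for a phenyl group carrying an amine or a carboxylic acid, or for a longer chain in place of the phenyl group, remains open. Also open, from the compounds shown here alone, is how the number responds to replacing the nitrile on the other side of the shared core.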